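The source may report more compounds than this note shows. Statements on the series, on what has been measured and on what is new or still open speak of the compounds shown alone.

Working notes on the series: in a functional assay on HCT-116 cells (Homo sapiens) for cytotoxicity, read by sulforhodamine B assay, with a stated time of 48 h (on this read-out higher numbers stand for weaker inhibition and lower numbers for stronger inhibition), compound 1 (`CC(=O)n1nc(NC(=O)c2ccccc2)c2c1CN(C(=O)c1cccc([N+](=O)[O-])c1)C2`) gives 17300 nM and compound 2 (`CC(=O)n1nc(NC(=O)c2ccccc2)c2c1CN(C(=O)CCl)C2`) gives 4100 nM, the lower of the two numbers so far. Still unmeasured is compound 3 (`CC(=O)n1nc(NC(=O)c2ccccc2)c2c1CN(C(=O)c1ccncc1)C2`), which differs from compound 2 as follows: pyridin-4-yl in place of chloromethyl on a carbonyl carbon. In words, this is pyridin-4-yl in place of chloromethyl on a carbonyl carbon. Among the measured compounds shown here, one measured step bears on it: a 4.2-fold lower number from compound 1 to compound 2 (0.63 log units; beyond the scatter), with chloromethyl in place of 3-nitrophenyl on a carbonyl carbon. The new change runs the other way, from chloromethyl to an aromatic group, so a step of similar or somewhat smaller size towards a higher number is expected in this assay. Pyridin-4-yl itself has no measured precedent here, so the range stays wide. The estimated step is a 2.9-fold higher number from compound 2 to compound 3 (0.47 log units; beyond the scatter). Compound 3 is estimated at 12000 nM, with an expected range of 5000 nM to 30000 nM.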

Compound 3, half-maximal inhibitory concentration: 10000 nM
Compound 3: the middle estimate sits 1.2-fold (0.08 log units) above what was measured; low and high end bracket the measured number.
By their numbers in this assay, from the lowest: compound 2; then compounds 3 and 1 (each within the scatter of the next).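

In this assay the step of a 2.4-fold higher number from compound 2 to compound 3 (0.39 log units; beyond the scatter) shows that a second aromatic group on this carbonyl carbon, here with a ring nitrogen, also gives a higher number than chloromethyl, and compound 2 remains the lowest of the three. The two aromatic groups are not separated, as the step of a 1.7-fold lower number from compound 1 to compound 3 (0.24 log units; within the scatter) shows, so pyridin-4-yl and 3-nitrophenyl read alike and only chloromethyl stands apart so far. No supporting data explain the gap between chloromethyl and the aromatic groups.

The compounds shown leave open whether the gap follows the chlorine or the absence of a ring, which a plain methyl or a longer chain such as 2-chloroethyl on the same carbonyl carbon would address. Also open, as far as these compounds go, is how an amine such as morpholin-4-ylmethyl or an unsubstituted phenyl would read at this place.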